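A few compounds are considered here, and "the series" means these few. Any claim that something is new, unique, unknown or untested is made for them only; others in the source may bear on it.

Of the compounds shown here, three sharing one core have been tested in a functional assay on the whole organism (artery, strain albino) with Rattus norvegicus as the target, with a stated time of 120 min, at a dose of 10 mg/kg by the oral route; on this read-out lower numbers stand for less inhibition and higher numbers for more inhibition at the one dose given (going by the name of the read-out). Compound 1, `CC1=C(C(=O)Nc2ccc([N+](=O)[O-])cc2)C(c2ccc(Br)cc2)N=C(SCc2ccc(Cl)cc2)N1`, gives 13.9%. Compound 2, `CC1=C(C(=O)Nc2ccc([N+](=O)[O-])cc2)C(c2ccc(Br)cc2)N=C(SCc2ccc(F)cc2)N1`, gives 12.9%. Compound 3, `CC1=C(C(=O)Nc2ccc([N+](=O)[O-])cc2)C(c2cccc([N+](=O)[O-])c2)N=C(SCc2ccc(Cl)cc2)N1`, gives 12.4%. All three numbers sit within the scatter of one another, so the inhibition in this assay is level across them.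

Compound 2 differs from compound 1 by fluoro in place of chloro on an aromatic carbon. This change made the step of a number 1 percentage points lower from compound 1 to compound 2 (within the scatter).

Compound 4, `CC1=C(C(=O)Nc2ccc([N+](=O)[O-])cc2)C(c2cccc([N+](=O)[O-])c2)N=C(SCc2ccc(F)cc2)N1`, is the compound still to be measured. It differs from compound 3 by fluoro in place of chloro on an aromatic carbon. For the measured compounds named here, this is the same change as the one from compound 1 to compound 2, sitting at the same place in the words given for both, but made on a different core. The core of compound 3 differs from the core of compound 1 by 3-nitrophenyl in place of 4-bromophenyl on a saturated ring carbon, and that change made the step of a number 1.5 percentage points lower from compound 1 to compound 3 (within the scatter).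

The change from chloro to fluoro has been seen once, giving a number 1 percentage points lower from compound 1 to compound 2 (within the scatter), a step that lies within the scatter. Because that earlier step was a number 1 percentage points lower from compound 1 to compound 2 (within the scatter), the step from compound 3 to compound 4 is expected to be about as small, namely a number 1 percentage points lower from compound 3 to compound 4 (within the scatter). On this basis compound 4 is estimated at 11.4%, with a likely range from 4% to 19%.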

Compound 4, a percentage reported as inhibition, in the whole organism at one dose (the size of the read-out at that dose, not a potency): 13.4%
The estimate for compound 4 lay 2 percentage points below the measured number; measured number inside the range.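

In this assay, fluoro in place of chloro made a number 1 percentage points higher from compound 3 to compound 4 (within the scatter), and set beside the earlier case, this change shows no difference between the two cores that can be told from the scatter: the same change on two cores in this assay, a number 1 percentage points lower (within the scatter) from compound 1 to compound 2 and a number 1 percentage points higher (within the scatter) from compound 3 to compound 4, 2 percentage points apart, within the scatter of two such steps. The other change, 3-nitrophenyl in place of 4-bromophenyl, made a number 0.5 percentage points higher from compound 2 to compound 4 (within the scatter), and it also reads alike on both cores: the same change on two cores in this assay, a number 1.5 percentage points lower (within the scatter) from compound 1 to compound 3 and a number 0.5 percentage points higher (within the scatter) from compound 2 to compound 4, 2 percentage points apart, within the scatter of two such steps. For the compounds shown here, every one of these steps lies within the scatter, so the agreement says only that neither change moved the number measurably on either core; it is no real test of whether a clear effect would carry from one core to another, and the opposite directions of the two fluoro steps are not a reversal.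

The compounds shown carry only chloro or fluoro on the benzyl ring, and only 4-bromophenyl or 3-nitrophenyl on the saturated ring carbon. Whether an amine or a methoxy group in place of the halogen, or a longer chain in place of the 4-fluorobenzyl, would move the number beyond the scatter stays open, as does how any of these compounds would behave at another dose.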